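Changing the Aromatic Ring of the Amide in Compound 1

This account rests on a few compounds, and the source may have more. Where it says the series, first, only, none or still open, it means among the compounds named here.

In a functional assay on the whole organism (blood) with Rattus norvegicus as the target, with stated times of 24 h and 1 h, at a dose of 15 mg/kg by the intraperitoneal route (on this read-out lower numbers stand for a weaker effect and higher numbers for a stronger effect at the one dose given), compound 1 `O=C(NC[C@@H]1C[C@@H]2C=C[C@@H]1C2)NS(=O)(=O)N1CCC(CCNC(=O)c2cnsc2)CC1` gives 14%.
In this assay compound 2 `CSc1ccc(C(F)(F)F)cc1C(=O)NCCC1CCN(S(=O)(=O)NC(=O)NC2CCCCC2)CC1` gives 24%.
In this assay compound 3 `COc1ncccc1C(=O)NCCC1CCN(S(=O)(=O)NC(=O)NC2CCCCC2)CC1` gives 35%.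

Compound 1 stands lowest of the three, though its gap to compound 2 lies within the scatter; only compound 3 is clearly higher. Compound 4 `O=C(NC[C@@H]1C[C@@H]2C=C[C@@H]1C2)NS(=O)(=O)N1CCC(CCNC(=O)c2cc(Cl)ccn2)CC1` differs from compound 1 by 4-chloropyridin-2-yl in place of 1,2-thiazol-4-yl on a carbonyl carbon. Among the measured compounds shown here, one measured step bears on this: exchanging the aromatic ring on the carbonyl carbon, a number 11 percentage points higher from compound 2 to compound 3 (beyond the scatter). That step concerns a different core and different rings, so it is only a loose guide; a modest upward step or none beyond the scatter is expected. Compound 4 is therefore estimated at 22%, between 8% and 40%, an expected a number 8 percentage points higher from compound 1 to compound 4 (within the scatter).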

Compound 4, a percentage reported as activity, at one dose (the size of the read-out at that dose, not a potency): 46%
Beside the measured number, compound 4's estimate is 24 percentage points below it, outside the stated range (above it).
By their numbers in this assay, from the lowest: compounds 1 and 2 (each within the scatter of the next); then compound 3; then compound 4.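

On the core of compound 1, the aromatic ring on the carbonyl carbon has a large say in the read-out: in this assay, 4-chloropyridin-2-yl in place of 1,2-thiazol-4-yl gives a number 32 percentage points higher from compound 1 to compound 4 (beyond the scatter). The earlier compounds shown here offered only a ring exchange on a different core, whereas this step is measured directly on this one. Nothing available explains the rise.

The exchange replaces the ring and brings in chlorine together, so the compounds shown leave open which of the two matters. A plain pyridin-2-yl on the same carbonyl carbon would separate them.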